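The compounds below may be only part of what the source reports. "The series", "measured", "known", "first", "only" and "open" are said of these compounds alone.

Three compounds share a chalcone-type scaffold and were tested in an assay on isolated protein for inhibition of DNA topoisomerase 1 (Homo sapiens), tested at 100 uM; a lower number here means a weaker effect, a higher number a stronger effect of the compound at the concentration tested. Compound 3 `COc1cc(O)ccc1C(=O)/C=C/c1ccc(F)cc1` gives 86.1%. Compound 2 `O=C(/C=C/c1ccc(F)cc1)c1ccc(O)cc1O` gives 80.2%. The two differ in one place, (hydrogen in place of methyl on an oxygen on an aromatic ring), and this change gave a number 5.9 percentage points lower from compound 3 to compound 2 (within the scatter). Compound 1 `COc1ccc(C(=O)/C=C/c2ccc(OC)c(Br)c2)c(O)c1` stands apart: in this assay compound 1 gives 5%, far beneath both others. The difference between the core of compound 1 and the core of compound 3 is not broken down here.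

Compound 4 `COc1ccc(/C=C/C(=O)c2ccc(O)cc2O)cc1Br` has not yet been measured in this assay. It differs from compound 1 by hydrogen in place of methyl on an oxygen on an aromatic ring, the same change that turned compound 3 into compound 2, at a place described in identical words. Because that step, a number 5.9 percentage points lower from compound 3 to compound 2 (within the scatter), stayed within the scatter, a similarly small step is expected here too, namely a number 7 percentage points higher from compound 1 to compound 4 (within the scatter), though a single prior example is a thin basis. Compound 4 is therefore expected to give 12% in this assay, most likely between 0% and 40%.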

Compound 4, a percentage reported as inhibition, at one concentration (the size of the read-out at that concentration, not a potency): 73.2%
Beside the measured number, compound 4's estimate is 61.2 percentage points below it, outside the stated range (above it).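

In this assay, exchanging methoxy for hydroxy on the core of compound 1 gave a large step, a number 68.2 percentage points higher from compound 1 to compound 4 (beyond the scatter). Within the data shown here, the same exchange therefore does not carry over from one core to another as a fixed amount: the same change on two cores in this assay, a number 5.9 percentage points lower (within the scatter) from compound 3 to compound 2 and a number 68.2 percentage points higher (beyond the scatter) from compound 1 to compound 4, 74.1 percentage points apart, beyond the scatter of two such steps This shows that the result of the exchange depends on the core it is made on, but with only two pairs it does not show which difference between the cores is responsible, nor does it give a reason for the gap or predict the step on a further core.

The compounds shown leave open what other groups at this oxygen would do, for example an ethyl group or a longer chain. They also leave open whether an amine or a carboxylic acid in place of the hydroxy group would keep the read-out as high as it is in compound 4.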